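Thiourea to tosyl sulfonamide on the anilide nitrogen

The compounds below may be only part of what the source reports. "The series", "measured", "known", "first", "only" and "open" are said of these compounds alone.

Compound 1 `CC(=O)O[C@@H]1[C@@H](OC(C)=O)[C@H](OC(C)=O)CO[C@H]1CC(=O)/C=C/c1cccc(NC(=S)Nc2ccccc2)c1` sits at the low end of the two numbers recorded so far in an ADME assay on Vero cells (Chlorocebus sabaeus) for cytotoxicity, read by resazurin assay, with a stated time of 2 days; on this read-out higher numbers stand for lower toxicity in this test and lower numbers for higher toxicity in this test: compound 1 gives 58700 nM, while compound 2 `CC(=O)OC[C@H]1O[C@@H](CC(=O)/C=C/c2cccc(NC(=S)Nc3ccccc3)c2)[C@H](OC(C)=O)[C@@H](OC(C)=O)[C@@H]1OC(C)=O` gives 337000 nM. Among the measured compounds shown here, the only step measured, a 5.7-fold higher number from compound 1 to compound 2 (0.76 log units; beyond the scatter), concerns the saturated part of the core and says nothing about the aryl side of the molecule.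

Compound 3 `CC(=O)O[C@@H]1[C@@H](OC(C)=O)[C@H](OC(C)=O)CO[C@H]1CC(=O)/C=C/c1cccc(NS(=O)(=O)c2ccc(C)cc2)c1` keeps the core of compound 1 and changes the terminal group: a group of 10 heavy atoms (7 carbon, 2 oxygen, 1 sulfur; one six-membered aromatic ring of carbon only) in place of a group of 9 heavy atoms (7 carbon, 1 nitrogen, 1 sulfur; one six-membered aromatic ring of carbon only), on a nitrogen on an aromatic ring. For the measured compounds named here, no measured pair in this set bears on this exchange, so the expectation rests on the starting number alone and carries a wide range. With the thiourea removed and a sulfonamide in its place, the number is expected to drift toward less toxicity rather than more, but not with any confidence beyond the scatter. The step expected for compound 3 is modest, a 1.7-fold higher number from compound 1 to compound 3 (0.23 log units; within the scatter). Compound 3 is estimated at 100000 nM in this assay, with a plausible range from 30000 nM to 350000 nM.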

Compound 3, half-maximal cytotoxic concentration: 268000 nM
Compound 3: the middle estimate sits 2.7-fold (0.43 log units) below what was measured; the measured number falls inside the stated range.
By their numbers in this assay, from the lowest: compound 1; then compounds 3 and 2 (each within the scatter of the next).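

In this assay, the group on the nitrogen on an aromatic ring proves to matter: (4-methylphenyl)sulfonyl in place of the phenyl thiourea group gives a 4.6-fold higher number from compound 1 to compound 3 (0.66 log units; beyond the scatter). The aryl side of the molecule therefore moves this number as well as the saturated part of the core, and on the core of compound 1 this exchange goes toward lower toxicity in this test. Nothing available explains the step, which stands here as an observation only.

On these data alone, the exchange alters the link and the terminal group together, so it remains open whether the step follows the loss of the thiourea or the arrival of the sulfonyl group; a urea, with oxygen in place of the sulfur, and a methanesulfonyl or unsubstituted benzenesulfonyl group on the same nitrogen would help to separate these. As far as these compounds go, it also remains open whether the (4-methylphenyl)sulfonyl group gives a step of similar size on the core of compound 2, where the acetoxymethyl group is present.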